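Swapping one ring on the carbonyl of compound 2

This account rests on a few compounds, and the source may have more. Where it says the series, first, only, none or still open, it means among the compounds named here.

In a functional assay on MCF7 cells (Homo sapiens) for antiproliferative activity, with a stated time of 5 days (a higher number here means a weaker inhibitor, a lower number a stronger inhibitor), compound 1 (`COc1ccc(-c2[nH]c3ccc(C)cc3c2C=O)cc1`) gives 140 nM while compound 2 (`CCCCc1ccc2[nH]c(-c3ccc(OC)cc3)c(/C=N/NC(=O)c3ccc(F)cc3)c2c1`) gives 84 nM and compound 3 (`CCCCc1ccc2[nH]c(-c3ccc(C(F)(F)F)cc3)c(/C=N/NC(=O)c3ccncc3)c2c1`) gives 100 nM as its reading. Compound 2 stands level with the other two, as all three numbers lie within the usual scatter of repeated measurements. Compound 4 (`CCCCc1ccc2[nH]c(-c3ccc(OC)cc3)c(/C=N/NC(=O)c3ccccn3)c2c1`) differs from compound 2 in one place, and the change pyridin-2-yl in place of 4-fluorophenyl on a carbonyl carbon puts pyridin-2-yl in place of 4-fluorophenyl on a carbonyl carbon. Within the data shown here, no measured pair shows such a swap alone. Compound 3 also has a ring with a hetero atom on that carbonyl and gives 100 nM as its reading, so no step beyond the scatter is expected in this assay in either direction. The estimated 1.4-fold higher number from compound 2 to compound 4 (0.15 log units; within the scatter) is expected to stay small. The expected value for compound 4 is 120 nM with a range of 50 nM to 300 nM around it.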

Compound 4, half-maximal inhibitory concentration: 160 nM
For compound 4 the middle estimate is 1.3-fold (0.12 log units) below the measured one; low and high end bracket the measured number.
By their numbers in this assay, from the lowest: compounds 2, 3, 1 and 4 (each within the scatter of the next).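

In this assay, among these compounds, this is the first swap at this carbonyl seen alone, and it gives a 1.9-fold higher number from compound 2 to compound 4 (0.28 log units; within the scatter). At this place, pyridin-2-yl can therefore stand in for 4-fluorophenyl with no step beyond the scatter, even though the entering ring brings one hydrogen-bond acceptor and the leaving ring brings none. Still open, on these data alone, is whether a ring carrying an amine or a carboxylic acid, or a longer chain in place of the ring, would shift the reading. No measurement here gives a reason for the size of this step.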